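This account rests on a few compounds, and the source may have more. Where it says the series, first, only, none or still open, it means among the compounds named here.

Compound 1 `CCN(CC)CCNC(=O)c1ccc(C(CC)(CC)c2ccc(OCCC(O)(CC)CC)c(C)c2)n1CC` is the reference point. In a functional assay on HepG2 cells (Homo sapiens) for antiproliferative activity, read by MTT assay, with a stated time of 48 h (a higher number here means a weaker inhibitor, a lower number a stronger inhibitor), compound 1 gives 230 nM, the lowest of the two numbers recorded, with compound 3 the nearest. Compound 2 `CCC(C)C(NC(=O)c1ccc(C(CC)(CC)c2ccc(OCCC(O)(CC)CC)c(C)c2)n1CC)C(=O)OC` carries a different group on the amide-type nitrogen, and in this assay compound 2 reaches only a limit of the assay, > 50000 nM, which is the limit of > 50000 nM in this assay, at which 1 of the 3 values shown sits. Compound 3 `CCOC(=O)CN(C)C(=O)c1ccc(C(CC)(CC)c2ccc(OCCC(O)(CC)CC)c(C)c2)n1CC` has ((ethoxycarbonyl)methyl)(methyl)amino on the carbonyl carbon and gives 25300 nM. Both changes from compound 1 cost a great deal: an at least 210-fold higher number from compound 1 to compound 2 (2.33 log units; beyond the scatter), and a 110-fold higher number from compound 1 to compound 3 (2.04 log units; beyond the scatter). Between the two weaker compounds, an at least 1.9-fold lower number from compound 2 to compound 3 (0.29 log units; that floor lies within the scatter).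

Compound 4 `CCn1c(C(=O)N(C)CCO)ccc1C(CC)(CC)c1ccc(OCCC(O)(CC)CC)c(C)c1` alters the same position: (2-hydroxyethyl)(methyl)amino in place of (2-(diethylamino)ethyl)amino on a carbonyl carbon. The two measured steps that start from compound 1 are the ones that bear on this change, since both remove the (2-(diethylamino)ethyl)amino group, and a large rise in the number is expected for compound 4 as well because an at least 210-fold higher number from compound 1 to compound 2 (2.33 log units; beyond the scatter) and a 110-fold higher number from compound 1 to compound 3 (2.04 log units; beyond the scatter) both went strongly in that direction. The entering group is smaller than those of compound 2 and compound 3, so the loss need not be as extreme. Compound 4 is estimated at 10000 nM, within 2000 nM to 50000 nM. That means an expected step of a 43-fold higher number from compound 1 to compound 4 (1.64 log units; beyond the scatter).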

Compound 4, half-maximal inhibitory concentration: 510 nM
Estimate against measurement, compound 4: 20-fold (1.29 log units) above; the whole stated range lies above it.
By their numbers in this assay, from the lowest: compound 1; then compound 4; then compound 3. At a limit, above all of these: compound 2.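

In this assay, within the data shown here, the earlier compounds left open the possibility that any replacement of (2-(diethylamino)ethyl)amino on this carbonyl carbon would ruin activity, but (2-hydroxyethyl)(methyl)amino costs only a modest amount, with a 2.2-fold higher number from compound 1 to compound 4 (0.35 log units; beyond the scatter). Compound 3 and compound 4 both carry a methyl on the amide nitrogen and differ only further out on the chain, where hydroxymethyl in place of ethoxycarbonyl gives a large change, with a 50-fold lower number from compound 3 to compound 4 (1.70 log units; beyond the scatter), so the loss in compound 3 goes with the ethoxycarbonyl group and not with that methyl. The gap to compound 2 is also large, with an at least 98-fold lower number from compound 2 to compound 4 (1.99 log units; beyond the scatter), though that step is measured from a limit of the assay and not from a number: the limit of > 50000 nM in this assay, at which 1 of the 4 values shown sits.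

Going by these compounds, whether the hydroxyl group of compound 4 itself contributes, or whether the gain simply comes from losing the ester, remains open, and a plain ethyl chain or a carboxylic acid at the same place would help separate the two. It is also unclear how (2-hydroxyethyl)amino, which keeps the amide hydrogen, or a longer chain ending in a hydroxyl group would compare with compound 4.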